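Swapping a Piperidine for a Piperazine on a Ceramidase Inhibitor

The compounds below may be only part of what the source reports. "The series", "measured", "known", "first", "only" and "open" are said of these compounds alone.

Measured so far:
compound 1 `CC(C)N1CCC(c2ccc3c(c2)oc(=O)n3C(=O)NCCCCc2ccccc2)CC1` gives 94 nM
compound 2 `CN1CCc2oc(=O)n(C(=O)NCCCCc3ccccc3)c2C1` gives 516 nM

Both compounds were tested in an assay on HEK293 cells for inhibition of acid ceramidase (Homo sapiens), read by fluorescence, with stated times of 10 min and 3 h; on this read-out higher numbers stand for weaker inhibition and lower numbers for stronger inhibition. Of the two numbers, compound 1 has the lower one, and the value of compound 2 lies higher by a margin beyond the usual scatter, so compound 1 is the stronger inhibitor of this pair.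

Compound 3 `CC(C)CN1CCN(c2ccc3c(c2)oc(=O)n3C(=O)NCCCCc2ccccc2)CC1` is not yet measured. It differs from compound 1 in one place: 4-isobutylpiperazin-1-yl in place of 1-isopropylpiperidin-4-yl on an aromatic carbon. The ring is kept, while a second nitrogen enters it and the side chain on that ring grows by one carbon. Within the data shown here, with only two measured compounds and no measured step of this type, the expected change is small; for compound 3 the step of a 1.6-fold higher number from compound 1 to compound 3 (0.20 log units; within the scatter) is expected to stay within or close to the scatter. Compound 3 is therefore estimated at 150 nM, with a range from 45 nM to 500 nM.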

Compound 3, half-maximal inhibitory concentration: 127 nM
Beside the measured number, compound 3's estimate is 1.2-fold (0.07 log units) above it; measured number inside the range.
By their numbers in this assay, from the lowest: compounds 1 and 3 (each within the scatter of the next); then compound 2.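

At this position on the aromatic carbon, 4-isobutylpiperazin-1-yl and 1-isopropylpiperidin-4-yl cannot be told apart in this assay, which shows a 1.4-fold higher number from compound 1 to compound 3 (0.13 log units; within the scatter). A second nitrogen in the ring and one more carbon in the side chain can therefore enter together without a difference beyond the scatter, something the earlier pair could not show, as its two members differ in more than one place. No measurement at hand bears on why the two groups read alike.

Going by these compounds, both alterations enter in this one step, so the share of each on its own stays unknown. Also open, on these data alone, is whether a morpholine ring, or a piperazine carrying an acetyl group instead of the isobutyl group, would read the same at this position.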